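Hydroxymethyl Moved One Bond Further Along the Chain

The source may report more compounds than this note shows. Statements on the series, on what has been measured and on what is new or still open speak of the compounds shown alone.

Compound 1 `CNc1nc(-c2ccccc2)nc2c1nnn2Cc1ccccc1F` gives 25000000 nM in an assay on isolated protein for binding affinity to adenosine receptor A1 (Bos taurus); on this read-out higher numbers stand for weaker inhibition and lower numbers for stronger inhibition. Compound 2 `OCCNc1nc(-c2ccccc2)nc2c1nnn2Cc1ccccc1F` gives 54000000 nM in this assay. Compound 3 `CCNc1nc(-c2ccccc2)nc2c1nnn2Cc1ccccc1F` gives 11000000 nM in this assay.

The three measured compounds share one core and differ only in the short chain attached to a nitrogen on an aromatic ring. Compound 1 and compound 3 differ by methyl in place of hydrogen on a saturated chain carbon bound to a nitrogen on an aromatic ring, and this gave a 2.3-fold lower number from compound 1 to compound 3 (0.36 log units; beyond the scatter). Compound 1 and compound 2 differ by hydroxymethyl in place of hydrogen on a saturated chain carbon bound to a nitrogen on an aromatic ring, which gave a 2.2-fold higher number from compound 1 to compound 2 (0.33 log units; beyond the scatter). Between the two larger chains the step is a 4.9-fold lower number from compound 2 to compound 3 (0.69 log units; beyond the scatter). Compound 3 therefore has the lowest number of the three, with both of its steps to the others beyond the scatter.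

Compound 4 `OCCCNc1nc(-c2ccccc2)nc2c1nnn2Cc1ccccc1F` has not yet been measured. It differs from compound 3 by hydroxymethyl in place of hydrogen on a saturated chain carbon, two bonds along the chain from a nitrogen on an aromatic ring. The change from compound 1 to compound 2 is the same kind of change, not the same one: there the hydroxymethyl enters on a saturated chain carbon bound to a nitrogen on an aromatic ring, whereas here it enters two bonds along the chain from that nitrogen. With that difference in place kept in mind, a similar modest rise in the number is expected.

Compound 4 is expected to show a step of a 2.0-fold higher number from compound 3 to compound 4 (0.30 log units; within the scatter) in this assay because the same kind of change made the step of a 2.2-fold higher number from compound 1 to compound 2 (0.33 log units; beyond the scatter). Compound 4 is estimated to give 22000000 nM, with a likely range from 8000000 nM to 60000000 nM.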

Compound 4, inhibition constant: 3700000 nM
Compound 4: the middle estimate sits 5.9-fold (0.77 log units) above what was measured; the measured number lies below the stated range.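

In this assay, hydroxymethyl in place of hydrogen, two bonds along the chain from a nitrogen on an aromatic ring, gave a 3.0-fold lower number from compound 3 to compound 4 (0.47 log units; beyond the scatter), so the direction of the earlier step did not carry over to this core, and the two steps differ clearly: the same change on two cores in this assay, a 2.2-fold higher number (0.33 log units; beyond the scatter) from compound 1 to compound 2 and a 3.0-fold lower number (0.47 log units; beyond the scatter) from compound 3 to compound 4, 6.4-fold (0.81 log units) apart, beyond the scatter of two such steps

The new chain also sets compound 4 apart from the other two compounds, with a 15-fold lower number from compound 2 to compound 4 (1.16 log units; beyond the scatter) and a 6.8-fold lower number from compound 1 to compound 4 (0.83 log units; beyond the scatter), which makes compound 4 the compound with the lowest number of the four. Going by these compounds alone, this shows that, in this series, the effect of adding hydroxymethyl depends on the carbon that receives it, so a step measured on one core is a poor guide to the step on another, but with only two such pairs it gives no general rule and does not explain the reversal.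

The compounds shown leave open whether a longer chain, such as 4-hydroxybutyl, would lower the number further or raise it again. They also leave open how an amine or a carboxylic acid in place of the hydroxy group of the 3-hydroxypropyl chain would compare with compound 4.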